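Replacing the 4-methylpiperazin-1-yl group of compound 3

The compounds below may be only part of what the source reports. "The series", "measured", "known", "first", "only" and "open" are said of these compounds alone.

In a functional assay on HL-60 cells (Homo sapiens) for antiproliferative activity, read by MTT assay, with a stated time of 48 h (a higher number here means a weaker inhibitor, a lower number a stronger inhibitor), compound 1 `COC/C1=C/C[C@](C)(CCC=C(C)C)/C=C/[C@@H](OC(=O)C=C(C)C)[C@](C)(O)/C=C/C1=O` gives 3070 nM, compound 2 `CC(C)=CCC[C@]1(C)/C=C/[C@@H](OC(=O)C=C(C)C)[C@](C)(O)/C=C/C(=O)/C(CCl)=C\C1` gives 160 nM, and compound 3 `CC(C)=CCC[C@]1(C)/C=C/[C@@H](OC(=O)C=C(C)C)[C@](C)(O)/C=C/C(=O)/C(CN2CCN(C)CC2)=C\C1` gives 840 nM. Compound 3 therefore holds the middle place among the three numbers, clearly separated from both of the others. All three share one core and differ only in the group on a saturated chain carbon bound to a double-bonded ring carbon.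

Compound 4 `CC(C)=CCC[C@]1(C)/C=C/[C@@H](OC(=O)C=C(C)C)[C@](C)(O)/C=C/C(=O)/C(Cn2cc(CO)nn2)=C\C1` changes that same place, with 4-(hydroxymethyl)-1H-1,2,3-triazol-1-yl in place of 4-methylpiperazin-1-yl on a saturated chain carbon bound to a double-bonded ring carbon.

All three measured steps bear on this change, since each was made at this place. The largest is a 19-fold lower number from compound 1 to compound 2 (1.28 log units; beyond the scatter). The two modest ones are a 3.7-fold lower number from compound 1 to compound 3 (0.56 log units; beyond the scatter) and a 5.3-fold higher number from compound 2 to compound 3 (0.72 log units; beyond the scatter). Among the compounds with values here, the number thus responds clearly to the group placed here, but no measured compound carries a triazole, so the direction rests on thin evidence. Only compound 2, at 160 nM, has a lower number than compound 3, and the remaining measured compound, compound 1, at 3070 nM, has a higher one. A modest move towards a higher number is therefore expected, and the estimated step is a 2.1-fold higher number from compound 3 to compound 4 (0.33 log units; beyond the scatter). For compound 4 the estimated value is 1800 nM, with an expected range of 600 nM to 5000 nM.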

Compound 4, half-maximal inhibitory concentration: 3200 nM
Compound 4: middle estimate off by 1.8-fold (0.25 log units), on the low side; the range from low to high includes it.
By their numbers in this assay, from the lowest: compound 2; then compound 3; then compounds 1 and 4 (each within the scatter of the next).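

In this assay, the 4-(hydroxymethyl)-1H-1,2,3-triazol-1-yl group falls on the weaker side of the 4-methylpiperazin-1-yl group, with a 3.8-fold higher number from compound 3 to compound 4 (0.58 log units; beyond the scatter) even though both groups have the same count of heavy atoms, and chloro keeps its lead, with a 20-fold higher number from compound 2 to compound 4 (1.30 log units; beyond the scatter) being the largest step among the new ones. With a 1.0-fold higher number from compound 1 to compound 4 (0.02 log units; within the scatter) as the remaining comparison, the triazole and methoxy groups cannot be told apart at this place, so two groups with different atoms and different ring content give the same reading here, and of the four groups only chloro and 4-methylpiperazin-1-yl stand clear of that level. No measurement offered here accounts for any of these differences.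

On these data alone, it remains open whether the triazole ring or its hydroxymethyl substituent sets the number for compound 4, a question that an unsubstituted triazole or a 4-(aminomethyl) triazole could address. As far as these compounds go, it is also open whether another halogen such as bromo, or a morpholin-4-yl ring, would come closer to chloro or to 4-methylpiperazin-1-yl on this saturated chain carbon.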